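The compounds below may be only part of what the source reports. "The series", "measured", "known", "first", "only" and "open" are said of these compounds alone.

Compound 1 `Cc1c(O)ccc2c1[C@H](Cn1cc(-c3ccc(Cl)cc3)nn1)[C@@]13CC(=O)[C@@](C)(CC[C@@H]21)C3` in a functional assay on HL-60 cells (Homo sapiens) for cytotoxicity, read by MTT assay, with a stated time of 4 days (a lower number here means a stronger inhibitor, a higher number a weaker inhibitor), gives only a limit, > 20000 nM.
Compound 2 `Cc1ccc(-c2cn(C[C@H]3c4c(ccc(O)c4C)[C@@H]4CC[C@@]5(C)C[C@]43CC5=O)nn2)cc1` in this assay gives only a limit, > 20000 nM.
Compound 3 `Cc1c(O)ccc2c1[C@H](Cn1cc(-c3ccc(C(F)(F)F)cc3)nn1)[C@@]13CC(=O)[C@@](C)(CC[C@@H]21)C3` in this assay gives only a limit, > 20000 nM.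

On these data alone, compound 1 thus stands where every value so far stands, at the limit of > 20000 nM in this assay, at which 3 of the 3 values shown sit, so its true potency is unknown beyond that boundary. Compound 4 `Cc1ccc(S(=O)(=O)Oc2ccc3c(c2C)[C@H](Cn2cc(-c4ccc(Cl)cc4)nn2)[C@@]24CC(=O)[C@@](C)(CC[C@@H]32)C4)cc1` differs from compound 1 by (4-methylphenyl)sulfonyl in place of hydrogen on an oxygen on an aromatic ring. Going by the values given here, the steps that bear on the question, a step that the two limits leave unreadable from compound 1 to compound 2 and a step that the two limits leave unreadable from compound 1 to compound 3, are both hidden by the limits, so no size or direction can be read from them. The expectation for compound 4 is therefore a step that the limit leaves unreadable from compound 1 to compound 4, most likely another limit. The estimate for compound 4 in this assay is 25000 nM, expected within 8000 nM to 80000 nM.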

Compound 4, half-maximal inhibitory concentration: > 20000 nM
Compound 4: only a limit was reported (the forecaster's own chance of this, stated with the estimate: 75%); the middle value lies beyond the limit too.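

Compound 1 and compound 4 each give only a limit, so the step between them cannot be read. The compounds shown leave open how strong any of them truly is and whether any of these changes matters: the limit of > 20000 nM in this assay, at which 4 of the 4 values shown sit.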